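Sulfamoyl to Methylsulfonyl on a Second Core

The source may report more compounds than this note shows. Statements on the series, on what has been measured and on what is new or still open speak of the compounds shown alone.

Compound 1, `Cc1cnc(Nc2ccc(S(C)(=O)=O)cc2)nc1Nc1nc2ccc(Cl)cc2s1`, in a functional assay on HCT-116 cells (Homo sapiens) for antiproliferative activity, read by MTT assay, with a stated time of 48 h; on this read-out lower numbers stand for stronger inhibition and higher numbers for weaker inhibition: 2500 nM
Compound 2, `Cc1cnc(Nc2ccc(S(N)(=O)=O)cc2)nc1Nc1nc2ccc(Cl)cc2s1`, in this assay: 2520 nM
Compound 3, `COc1ccc2nc(Nc3nc(Nc4ccc(S(N)(=O)=O)cc4)ncc3F)sc2c1`, in this assay: 11500 nM

Compounds 1 and 2 share one core and differ at a single spot: methyl in place of amino on a sulfonyl sulfur. That change made the step of a 1.0-fold lower number from compound 2 to compound 1 (0.00 log units; within the scatter), so on this core the two values show no difference that can be told apart from the noise of the measurement.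

Compound 3 sits on a different core. How the two cores differ is not broken down here. In this assay compound 3 gives the highest of the three numbers, and its gap to compound 2 and to compound 1 lies beyond the scatter.

Compound 4, `COc1ccc2nc(Nc3nc(Nc4ccc(S(C)(=O)=O)cc4)ncc3F)sc2c1`, has not yet been measured. It relates to compound 3 exactly as compound 1 relates to compound 2: methyl in place of amino on a sulfonyl sulfur. The place of the change is described in the same words for both pairs, so this is the same change carried over to the second core.

Within the data shown here, the expectation for compound 4 therefore rests on the one measured example of this change. Because compound 2 to compound 1 gave a 1.0-fold lower number from compound 2 to compound 1 (0.00 log units; within the scatter), compound 4 is expected to show a step of about no change at the digits printed from compound 3 to compound 4 (within the scatter) from compound 3 in this assay. Whether a change that was flat on one core stays flat on another is not settled by two examples, so the range is kept wide. Compound 4 is estimated at 11500 nM in this assay, with a likely range from 5000 nM to 26000 nM.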

Compound 4, half-maximal inhibitory concentration: 2630 nM
Compound 4: middle estimate off by 4.4-fold (0.64 log units), on the high side; the measured number lies below the stated range.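

In this assay, putting methyl in place of amino on the sulfonyl sulfur gave a 4.4-fold lower number from compound 3 to compound 4 (0.64 log units; beyond the scatter) and so brought a real gain in this cell assay on the core of compound 3, whereas the same swap on the core of compound 2 left the number unchanged. A change that does nothing on one core therefore cannot be assumed to do nothing on another in this series, and the two steps differ by more than ordinary measurement noise: the same change on two cores in this assay, a 1.0-fold lower number (0.00 log units; within the scatter) from compound 2 to compound 1 and a 4.4-fold lower number (0.64 log units; beyond the scatter) from compound 3 to compound 4, 4.3-fold (0.64 log units) apart, beyond the scatter of two such steps

Among these compounds, with only one matched pair on each core, meaning two compounds that differ in a single place, these results show that the size of the step depends on the core, but not which part of the core is responsible, nor what the swap would do on a third core.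

Going by these compounds, it remains open whether a longer chain such as ethyl on the sulfonyl sulfur, or a substituted amine such as dimethylamino in the same place, would give a flat step or a clear gain on each core. The compounds shown also include no pair that differs in just one place on the core, so the separate parts of the core cannot yet be tested one at a time.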